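A few compounds are considered here, and "the series" means these few. Any claim that something is new, unique, unknown or untested is made for them only; others in the source may bear on it.

The measured compounds in an ADME assay on Vero cells (Chlorocebus sabaeus) for cytotoxicity, with a stated time of 72 h; a lower number here means that less compound is tolerated, a higher number that more compound is tolerated:
compound 1, `CN1CCN(c2ccc(C(=O)C3CC3c3ccc(Cl)cc3)cc2)CC1`, gives 82.1 ug/mL;
compound 2, `O=C(c1ccc(NC2CCCCC2)cc1)C1CC1c1ccc(Cl)cc1`, gives 196 ug/mL;
compound 3, `O=C(c1ccc(NCc2ccco2)cc1)C1CC1c1ccc(Cl)cc1`, gives 256 ug/mL.

Compound 2 holds the second highest of the three numbers. Its nearest neighbour is compound 3, reached by a 1.3-fold higher number from compound 2 to compound 3 (0.12 log units; within the scatter); its furthest is compound 1, from which it is reached by a 2.4-fold higher number from compound 1 to compound 2 (0.38 log units; beyond the scatter). Compound 4, `O=C(c1ccc(NCCO)cc1)C1CC1c1ccc(Cl)cc1`, differs from compound 2 in one place: 2-hydroxyethyl in place of cyclohexyl on a nitrogen on an aromatic ring.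

For the measured compounds named here, only one measured step touches the same place, the exchange of the group on the nitrogen on an aromatic ring from compound 2 to compound 3, and that step stayed within the scatter. The two modest steps from compound 1, a 2.4-fold higher number from compound 1 to compound 2 (0.38 log units; beyond the scatter) and a 3.1-fold higher number from compound 1 to compound 3 (0.49 log units; beyond the scatter), replace the 4-methylpiperazin-1-yl altogether and so do not speak to a change made on the nitrogen that is kept. On this basis the expected step for compound 4 in this assay is a 1.1-fold higher number from compound 2 to compound 4 (0.05 log units; within the scatter), that is, none beyond the scatter. Compound 4 is therefore estimated at 220 ug/mL, with a range from 120 ug/mL to 400 ug/mL.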

Compound 4, half-maximal cytotoxic concentration: 305 ug/mL
The estimate for compound 4 lay 1.4-fold (0.14 log units) below the measured number, and the stated range covers the measured number.
By their numbers in this assay, from the lowest: compound 1; then compounds 2, 3 and 4 (each within the scatter of the next).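

In this assay, 2-hydroxyethyl in place of cyclohexyl on the nitrogen on an aromatic ring gives a step that stays inside the scatter (a 1.6-fold higher number from compound 2 to compound 4 (0.19 log units; within the scatter)), and the same holds for hydroxymethyl in place of furan-2-yl on the saturated chain carbon (a 1.2-fold higher number from compound 3 to compound 4 (0.08 log units; within the scatter)). The nitrogen thus carries cyclohexyl, (furan-2-yl)methyl and 2-hydroxyethyl, a carbon ring and an open chain with a hydrogen-bond donor among them, without a separable difference, while the exchange of 4-methylpiperazin-1-yl remains beyond the scatter with this third group (a 3.7-fold higher number from compound 1 to compound 4 (0.57 log units; beyond the scatter)). Nothing measured here accounts for these numbers.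

Open, as far as these compounds go, is whether a 2-aminoethyl or carboxymethyl group on this nitrogen would leave the number within the scatter as well. From the compounds shown here alone, a longer chain ending in hydroxyl, or an unsubstituted piperazin-1-yl in place of 4-methylpiperazin-1-yl, also remains open.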